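Sulfanyl substitution on the shared core: ethoxycarbonyl variant

The source may hold more compounds than are shown below. What is called first, only, known or untested is meant among the compounds shown, and "the series" means these compounds.

The series places a substituent on one aromatic carbon of the shared core of compound 1 `O=C(CCCN1CCC(n2cnc3ccccc32)CC1)c1ccc(F)cc1`. In a functional assay on the whole organism (strain STD-ddY) for inhibition, with Mus musculus as the target, with a stated time of 5 min (a lower number here means that less compound is needed, a higher number that more compound is needed for the effect), compound 1 gives 4.7 mg/kg. Compound 2 `O=C(CCCN1CCC(n2c(SCCO)nc3ccccc32)CC1)c1ccc(F)cc1` carries (2-hydroxyethyl)sulfanyl there and gives 6.9 mg/kg; compound 3 `O=C(CCCN1CCC(n2c(SCC(=O)c3ccc(Cl)cc3)nc3ccccc32)CC1)c1ccc(F)cc1` carries (((4-chlorophenyl)carbonyl)methyl)sulfanyl and gives 5 mg/kg. The steps run a 1.5-fold higher number from compound 1 to compound 2 (0.17 log units; within the scatter) and a 1.1-fold higher number from compound 1 to compound 3 (0.03 log units; within the scatter), and between the two substituted compounds a 1.4-fold lower number from compound 2 to compound 3 (0.14 log units; within the scatter), so all three numbers sit within the scatter of one another and compound 1 is not separated from either neighbour.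

Compound 4 `CCOC(=O)Sc1nc2ccccc2n1C1CCN(CCCC(=O)c2ccc(F)cc2)CC1` differs from compound 1 by (ethoxycarbonyl)sulfanyl in place of hydrogen on an aromatic carbon. Both measured substitutions at this carbon, one small and polar, one large, left the number essentially unchanged, so no step beyond the scatter is expected for compound 4 in this assay, in either direction. The estimate for compound 4 is 5.5 mg/kg, with a range of 3 mg/kg to 10 mg/kg, a step of a 1.2-fold higher number from compound 1 to compound 4 (0.07 log units; within the scatter) that is expected to stay within the scatter.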

Compound 4, dose for half-maximal effect: 0.36 mg/kg
Compound 4: the middle estimate sits 15-fold (1.18 log units) above what was measured; the whole stated range lies above it.
By their numbers in this assay, from the lowest: compound 4; then compounds 1, 3 and 2 (each within the scatter of the next).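

Among the compounds shown here, the aromatic carbon between two ring nitrogen atoms does respond to substitution in this assay: (ethoxycarbonyl)sulfanyl gives a 13-fold lower number from compound 1 to compound 4 (1.12 log units; beyond the scatter) with no counterpart among the earlier sulfanyl groups. With the sulfur kept, the group on it makes the difference: ethoxycarbonyl in place of ((4-chlorophenyl)carbonyl)methyl gives a 14-fold lower number from compound 3 to compound 4 (1.14 log units; beyond the scatter) and in place of 2-hydroxyethyl gives a 19-fold lower number from compound 2 to compound 4 (1.28 log units; beyond the scatter) in the same assay. Nothing shown bears on why the number falls with this group.

Open, on these data alone, is whether the sulfur is needed at all, as an ethoxycarbonyl bound directly to the aromatic carbon would show. Also open, as far as these compounds go, is whether other groups on the sulfur, such as methoxycarbonyl, a carboxylic acid or a dimethylcarbamoyl, would reach the number of compound 4.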